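Chloro to Bromo Swap in a Hydroxamic Acid Series

This account rests on a few compounds, and the source may have more. Where it says the series, first, only, none or still open, it means among the compounds named here.

Compound 1 `O=C(CCCCCCN1C(=O)/C(=N\O)c2cc(Cl)ccc21)NO` and compound 2 `O=C(CCCCCCN1C(=O)/C(=N\O)c2cc(Br)ccc21)NO` share one core, while compound 3 `CO/N=C1/C(=O)N(CCCCCCC(=O)NO)c2ccc(Cl)cc21` and the as yet unmeasured compound 4 `CO/N=C1/C(=O)N(CCCCCCC(=O)NO)c2ccc(Br)cc21` share another; the difference between the two cores is not broken down here. In a functional assay on PC-3 cells (Homo sapiens) for antiproliferative activity, read by sulforhodamine B assay, with a stated time of 48 h (on this read-out higher numbers stand for weaker inhibition and lower numbers for stronger inhibition), compound 1 gives 850 nM and compound 2 gives 2210 nM. The change between them is bromo in place of chloro on an aromatic carbon, and it made a 2.6-fold higher number from compound 1 to compound 2 (0.41 log units; beyond the scatter). In this assay compound 3 gives 2330 nM, a number within the scatter of compound 2 and beyond the scatter against compound 1. Compound 4 differs from compound 3 by bromo in place of chloro on an aromatic carbon, the same change at a place described in the same words. The step expected from compound 3 to compound 4 is a 2.1-fold higher number from compound 3 to compound 4 (0.33 log units; beyond the scatter), because the same change earlier gave a 2.6-fold higher number from compound 1 to compound 2 (0.41 log units; beyond the scatter), though a single precedent leaves room for a smaller or larger shift. Compound 4 is therefore estimated at 5000 nM in this assay, expected to fall between 2000 nM and 12000 nM.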

Compound 4, half-maximal inhibitory concentration: 8910 nM
Compound 4: middle estimate off by 1.8-fold (0.25 log units), on the low side; low and high end bracket the measured number.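

In this assay, bromo in place of chloro on an aromatic carbon gave a 3.8-fold higher number from compound 3 to compound 4 (0.58 log units; beyond the scatter), so the number moved in the same direction on the core of compound 3 as on the core of compound 1. The two steps cannot be told apart in size: the same change on two cores in this assay, a 2.6-fold higher number (0.41 log units; beyond the scatter) from compound 1 to compound 2 and a 3.8-fold higher number (0.58 log units; beyond the scatter) from compound 3 to compound 4, 1.5-fold (0.17 log units) apart, within the scatter of two such steps. For the compounds shown here, this shows that the change carried over between these two cores in this one assay, with weaker inhibition for bromo in both pairs, but it rests on only two pairs and does not show why the number rises or that the step would hold on any other core.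

The compounds shown leave open how fluoro or iodo on that aromatic carbon would compare with chloro and bromo in this assay. They also leave open whether the same step would appear with a shorter or longer chain ending in the hydroxamic acid.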